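A methyl on the amide-type nitrogen of compound 3

The compounds below may be only part of what the source reports. "The series", "measured", "known", "first", "only" and "open" are said of these compounds alone.

Measured so far in a functional assay on MCF7 cells (Homo sapiens) for inhibition; a lower number here means a stronger inhibitor, a higher number a weaker inhibitor:
- compound 1 `CCCCNC(=O)N1CC1C#N` gives only a limit, > 12000 nM.
- compound 2 `N#CC1CN1C(=O)Nc1ccc(F)cc1` gives 1900 nM.
- compound 3 `N#CC1CN1C(N)=O` gives only a limit, > 54000 nM.

Compound 3 thus stands at a limit of this assay, not at a number; two of the three values are such limits, as the limit of > 12000 nM in this assay, at which 1 of the 3 values shown sits, and the limit of > 54000 nM in this assay, at which 1 of the 3 values shown sits, show. Compound 4 `CNC(=O)N1CC1C#N` differs from compound 3 by methyl in place of hydrogen on an amide-type nitrogen. Among the measured compounds shown here, the only measured step at this position, a step that the two limits leave unreadable from compound 1 to compound 3, cannot be read, since both of its ends are limits. For the measured compounds named here, compound 2 carries a larger substituent on the same nitrogen, and no step to it is counted here, so its value shows only that a measurable number can occur. With compound 1 and compound 3 both at limits, a small group on this nitrogen is expected to leave compound 4 weak as well. The step from compound 3 is estimated to be an at least 1.3-fold lower number from compound 3 to compound 4 (0.13 log units; that floor lies within the scatter). Compound 4 is estimated at 40000 nM, with a range of 8000 nM to 200000 nM, most likely reported again as a limit.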

Compound 4, half-maximal inhibitory concentration: 27000 nM
Estimate against measurement, compound 4: 1.5-fold (0.17 log units) above; measured number inside the range.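

With methyl on the amide-type nitrogen, compound 4 gives a number in this assay, whereas butyl in compound 1 and hydrogen in compound 3 each leave only a limit. Methyl in place of hydrogen gives an at least 2.0-fold lower number from compound 3 to compound 4 (0.30 log units; that floor lies within the scatter), so the true size of this change remains unknown and only its floor can be stated. That floor rests on a limit, not a number, for compound 3: the limit of > 54000 nM in this assay, at which 1 of the 4 values shown sits.

The steps linking compound 1 to compound 3 and to compound 4 cannot be read. The compounds shown include no ethyl or propyl chain on this nitrogen, so it remains open how the values run between methyl and butyl, and whether a plain phenyl would behave like the fluorophenyl group of compound 2.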